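This account rests on a few compounds, and the source may have more. Where it says the series, first, only, none or still open, it means among the compounds named here.

Measured compounds:
Compound 1, `COc1ccc(-c2[nH]c3ccccc3c2/C=C(\C#N)S(=O)(=O)c2ccccc2)cc1`, gives 1100 nM in a functional assay on SF-268 cells (Homo sapiens) for inhibition, read by sulforhodamine B assay, with a stated time of 48 h; a lower number here means a stronger inhibitor of growth, a higher number a weaker inhibitor of growth.
Compound 2, `CC(=O)/C(=C\c1c(-c2ccccc2)[nH]c2ccccc12)S(=O)(=O)c1ccccc1`, gives 3400 nM in this assay.
Compound 3, `N#C/C(=C\c1c(-c2ccccc2)[nH]c2ccccc12)S(=O)(=O)c1ccccc1`, gives 4500 nM in this assay.

Compound 3 gives the highest of the three numbers in this assay. Its nearest neighbour is compound 2, from which a 1.3-fold higher number from compound 2 to compound 3 (0.12 log units; within the scatter), a step that stays within the scatter; the furthest is compound 1, from which a 4.1-fold higher number from compound 1 to compound 3 (0.61 log units; beyond the scatter).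

Compound 4, `N#C/C(=C\c1c(-c2ccccc2)[nH]c2ccccc12)C(=O)c1ccccc1`, differs from compound 3 in one place: benzoyl in place of phenylsulfonyl on a double-bonded chain carbon bound to a double-bonded chain carbon and a triple-bonded carbon. Neither measured step concerns this group. The step from compound 1 to compound 3 changes a group on the aromatic ring of the shared core, and the step from compound 2 to compound 3 swaps the other substituent on the same chain carbon, where acetyl against cyano made no difference beyond the scatter. Among the compounds with values here, the present change has no direct precedent among the three measured compounds. Within the data shown here, with the one swap on this carbon having left the number unchanged within the scatter, a step in this assay of modest size at most, in either direction, is expected, and the estimated step is a 1.1-fold lower number from compound 3 to compound 4 (0.05 log units; within the scatter). Compound 4 is expected to give about 4000 nM in this assay, within a range of 1300 nM to 12000 nM.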

Compound 4, concentration for 50% growth inhibition: 5700 nM
For compound 4 the middle estimate is 1.4-fold (0.15 log units) below the measured one, within the range that was stated.
By their numbers in this assay, from the lowest: compound 1; then compounds 2, 3 and 4 (each within the scatter of the next).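

In this assay, benzoyl in place of phenylsulfonyl on a double-bonded chain carbon bound to a double-bonded chain carbon and a triple-bonded carbon gives a 1.3-fold higher number from compound 3 to compound 4 (0.10 log units; within the scatter), a step within the scatter even though the sulfur leaves with the phenylsulfonyl group. The earlier compounds shown here showed only that cyano in place of acetyl, on the chain carbon that also bears phenylsulfonyl, gave a 1.3-fold higher number from compound 2 to compound 3 (0.12 log units; within the scatter); the new step shows that the phenylsulfonyl group can also be exchanged, for benzoyl, with no change in the number beyond the scatter. No evidence available here bears on the cause of this result.

On these data alone, the hydrogen in place of methoxy on the aromatic ring gave a 4.1-fold higher number from compound 1 to compound 3 (0.61 log units; beyond the scatter) with phenylsulfonyl on the chain, and whether that step carries over when benzoyl stands there remains open. Also open, as far as these compounds go, is what this assay would read with a group of a different kind in the benzoyl position, such as a primary amide, a carboxylic acid or a longer alkyl chain.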